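Amino in place of methyl on the anilino ring

A few compounds are considered here, and "the series" means these few. Any claim that something is new, unique, unknown or untested is made for them only; others in the source may bear on it.

Measured so far:
compound 1, `Cc1ccc(Nc2ncnc3c2nnn3Cc2ccccc2Cl)cc1`: 119 nM
compound 2, `O=[N+]([O-])c1cccc(Nc2ncnc3c2nnn3Cc2ccccc2)c1`: 443 nM

Compound 1 gives the lower of the two numbers in an assay on cell membranes for binding affinity to adenosine receptor A1 (Bos taurus), read by radioligand binding; a lower number here means a stronger inhibitor, a higher number a weaker inhibitor; compound 2 gives the higher, and the gap between them lies beyond the usual scatter. Compound 3, `Nc1ccc(Nc2ncnc3c2nnn3Cc2ccccc2Cl)cc1`, has not yet been measured. It is made from compound 1 by one change, (amino in place of methyl on an aromatic carbon), which amounts to an amino in place of a methyl on an aromatic carbon. Going by the values given here, no measured pair shows this exact change, so its effect here is unknown. The expectation is a small step, from compound 1 to compound 3 of a 2.1-fold higher number from compound 1 to compound 3 (0.32 log units; beyond the scatter), most likely within the scatter or leaning toward a somewhat higher number. Compound 3 is therefore estimated at 250 nM, with a range from 60 nM to 1000 nM.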

Compound 3, inhibition constant: > 1000 nM
Compound 3 gave a limit, no number (the forecaster's own chance of this, stated with the estimate: 5%); at least 4.0-fold (0.60 log units) between middle value and limit.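

In this assay, compound 3 carries a limit of the assay, not a number: the limit of > 1000 nM in this assay, at which 1 of the 3 values shown sits.

Even so, replacing the methyl with an amino group, on an aromatic carbon para to a large group, gives an at least 8.4-fold higher number from compound 1 to compound 3 (0.92 log units; beyond the scatter). This position is therefore not indifferent to which small group it carries. Methyl and amino each have one heavy atom, yet exchanging one for the other, which brings in one hydrogen-bond donor and one hydrogen-bond acceptor, moves the number beyond the scatter.

These compounds cannot tell whether the donor, the acceptor or the missing methyl matters most. From the compounds shown here alone, how a hydroxyl, a methoxy group or a plain hydrogen at this place would compare also stays open, as does the true size of this step.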